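Acetamido addition on the furoxan-coumarin series

This account rests on a few compounds, and the source may have more. Where it says the series, first, only, none or still open, it means among the compounds named here.

Measured so far:
compound 1 `COc1cc2ccc(=O)oc2cc1OCCCOc1no[n+]([O-])c1S(=O)(=O)c1ccccc1`: 2900 nM
compound 2 `COc1cc2cc(NC(C)=O)c(=O)oc2cc1OCCOc1no[n+]([O-])c1S(=O)(=O)c1ccccc1`: 4830 nM

For the measured compounds named here, in a functional assay on HepG2 cells (Homo sapiens) for inhibition, read by MTT assay, with a stated time of 48 h (on this read-out lower numbers stand for stronger inhibition and higher numbers for weaker inhibition), compound 1 gives 2900 nM, the lowest of the two numbers so far. Compound 2 gives 4830 nM in this assay; the two values lie within the usual scatter of each other, so no order between them can be read from the data.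

Compound 3 `COc1cc2cc(NC(C)=O)c(=O)oc2cc1OCCCOc1no[n+]([O-])c1S(=O)(=O)c1ccccc1` is not yet measured in this assay. Relative to compound 1 the change is acetamido in place of hydrogen on an aromatic carbon. Going by the values given here, no directly comparable step between measured compounds exists, so the size of this change has to be judged from what is at hand. Compound 2 already carries the acetamido group and sits within the scatter of compound 1, which gives no sign that this group moves the number far in either direction.

The expectation is therefore a step of a 1.3-fold higher number from compound 1 to compound 3 (0.12 log units; within the scatter) from compound 1 to compound 3, that is, no shift beyond the scatter. Compound 3 is estimated at 3800 nM in this assay, with a range from 1500 nM to 9500 nM.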

Compound 3, half-maximal inhibitory concentration: 2820 nM
Estimate against measurement, compound 3: 1.3-fold (0.13 log units) above; measured number inside the range.
By their numbers in this assay, from the lowest: compounds 3, 1 and 2 (each within the scatter of the next).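

In this assay, for the compounds shown here, the pair of compound 1 and compound 3 gives the first readable step, a 1.0-fold lower number from compound 1 to compound 3 (0.01 log units; within the scatter), for acetamido in place of hydrogen on this aromatic carbon, two atoms from the ring oxygen. Compound 2 could not show this, as it differs from compound 1 in more than one place. On the core of compound 1, this position therefore takes acetamido, with its 4 heavy atoms, without a step beyond the scatter. Nothing at hand explains the result or says what lies behind it.

From the compounds shown here alone, one substituent at one position on one chain length is a narrow basis, and whether acetamido would behave the same way on the chain of compound 2 stays open. Going by these compounds alone, also open is whether a free amine or a carboxylic acid on this aromatic carbon, or a longer chain than the one in compound 3 between the core and the sulfonyl-bearing ring, would move the number beyond the scatter.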